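The source may report more compounds than this note shows. Statements on the series, on what has been measured and on what is new or still open speak of the compounds shown alone.

Compounds measured so far:
- compound 1, `CC1CCN(c2c(S(=O)(=O)c3cccc(F)c3)cnc3ccc(F)cc23)CC1`: 76%
- compound 2, `CC1CCN(c2c(S(=O)(=O)c3ccc(F)c(Cl)c3)cnc3ccc(F)cc23)CC1`: 95%
- compound 3, `Cc1ccc(S(=O)(=O)c2cnc3ccc(F)cc3c2N2CCC(C)CC2)cc1Cl`: 91%

In an assay on isolated protein for displacement of a labelled ligand from metabotropic glutamate receptor 5 (Homo sapiens), with a stated time of 60 min, tested at 1 uM (a lower number here means less inhibition, a higher number more inhibition at the concentration tested (going by the name of the read-out)), compound 3 stands second of the three numbers; its nearest neighbour is compound 2, where the step of a number 4 percentage points lower from compound 2 to compound 3 (within the scatter) lies within the scatter, and its furthest is compound 1, where the step of a number 15 percentage points higher from compound 1 to compound 3 (beyond the scatter) lies beyond it. Compound 2 and compound 3 therefore cannot be ordered against each other on these numbers.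

The next compound is compound 4, `CC1CCN(c2c(S(=O)(=O)c3cccc(C#N)c3)cnc3ccc(F)cc23)CC1`. It differs from compound 3 in one place: 3-cyanophenyl in place of 3-chloro-4-methylphenyl on a sulfonyl sulfur.

For the measured compounds named here, no measured step bears on this change directly. The two steps that start from the 3-fluorophenyl of compound 1, a number 19 percentage points higher from compound 1 to compound 2 (beyond the scatter) and a number 15 percentage points higher from compound 1 to compound 3 (beyond the scatter), both gain on going to a 3-chloro-4-methylphenyl or 3-chloro-4-fluorophenyl ring, while the 3-fluorophenyl of compound 1 gives 76%. Compound 4 again carries a ring with a single substituent, a 3-cyanophenyl, so the gain seen for compound 2 and compound 3 is not expected to carry over; a return toward the level of compound 1 is expected instead, with a step of a number 13 percentage points lower from compound 3 to compound 4 (beyond the scatter). Compound 4 is estimated at 78%, within 60% to 92%, in this assay.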

Compound 4, a percentage reported as inhibition, at one concentration (the size of the read-out at that concentration, not a potency): 93%
Estimate against measurement, compound 4: 15 percentage points below; the whole stated range lies below it.
By their numbers in this assay, from the lowest: compound 1; then compounds 3, 4 and 2 (each within the scatter of the next).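

At this place on the sulfonyl sulfur, a ring with one substituent can reach the level of the chlorine-bearing rings in this assay, with a number 2 percentage points higher from compound 3 to compound 4 (within the scatter) and a number 2 percentage points lower from compound 2 to compound 4 (within the scatter). Cyano in place of fluoro alone gives a number 17 percentage points higher from compound 1 to compound 4 (beyond the scatter), so the gain over compound 1 does not require chlorine, and the count of ring substituents does not sort these compounds: compound 1 and compound 4 both carry one, yet they lie apart. No measurement shown here accounts for the difference between the cyano and fluoro compounds.

On these data alone, compound 2, compound 3 and compound 4 cannot be ordered at this single concentration, so any potency differences among them remain open. Also open, as far as these compounds go, is how a methoxy group, an amine or a carboxylic acid in place of the cyano would read out in this assay.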